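Benzyl in place of propargyl on the thioether of compound 2

A few compounds are considered here, and "the series" means these few. Any claim that something is new, unique, unknown or untested is made for them only; others in the source may bear on it.

Of the compounds shown here, three that share a core have been tested in a functional assay on MGC-803 cells (Homo sapiens) for antiproliferative activity, read by MTT assay, with a stated time of 72 h; a lower number here means a stronger inhibitor, a higher number a weaker inhibitor. Compound 2 `C#CCSc1nc(N/N=C/c2cc(OC)c(OC)c(OC)c2)c2nnn(Cc3ccccc3)c2n1` gives 4670 nM. Compound 3 `CCCSc1nc(N/N=C(\C)c2ccccc2O)c2nnn(Cc3cccc(Cl)c3)c2n1` gives 6500 nM, and compound 1 `CCCSc1nc(N/N=C(\C)c2ccccc2O)c2nnn(Cc3ccc(O)cc3)c2n1` gives 7680 nM; all three numbers lie within the scatter of one another, so none of them can be set apart from the others in this assay. Among the compounds with values here, the one measured step that differs in a single place, a 1.2-fold lower number from compound 1 to compound 3 (0.07 log units; within the scatter), changes the group on a saturated chain carbon bound to an aromatic nitrogen and leaves the number essentially where it was.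

Compound 4 `COc1cc(/C=N/Nc2nc(SCc3ccccc3)nc3c2nnn3Cc2ccccc2)cc(OC)c1OC` differs from compound 2 by phenyl in place of ethynyl on a saturated chain carbon bound to a sulfur. Within the data shown here, the measured step from compound 1 to compound 3 concerns a different position and therefore does not speak directly to this change; no measured step touches the group on the sulfur. With nothing in the data pointing to a movement in either direction, compound 4 is expected to sit close to compound 2, and the expected step of a 1.0-fold lower number from compound 2 to compound 4 (0.02 log units; within the scatter) is estimated to stay within the scatter. On that basis compound 4 is estimated at 4500 nM in this assay, with a range from 1500 nM to 13000 nM.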

Compound 4, half-maximal inhibitory concentration: 1320 nM
Estimate against measurement, compound 4: 3.4-fold (0.53 log units) above; measured number below the stated range.
By their numbers in this assay, from the lowest: compound 4; then compounds 2, 3 and 1 (each within the scatter of the next).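

Within the data shown here, the group on the sulfur matters in this assay: benzyl in place of propargyl gives a 3.5-fold lower number from compound 2 to compound 4 (0.55 log units; beyond the scatter) and so produces the only change in this set that lies beyond the scatter. The one earlier step, on a saturated chain carbon bound to an aromatic nitrogen, had left the number essentially unchanged, so the thioether is the first place shown here where a single change moves the read-out, with a modest gain on swapping ethynyl for phenyl. Nothing measured here bears on why the number falls with this change.

The compounds shown leave open whether the aromatic ring itself is what counts, or whether a cyclohexylmethyl group or a longer chain such as phenethyl on the sulfur would give a similar number. From the compounds shown here alone, it also remains open whether the same change would carry over to compound 1 and compound 3, which have propyl on the sulfur and differ from compound 2 and compound 4 in other places as well.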